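Benzyl to (oxolan-3-yl)methyl on the shared core

The source may hold more compounds than are shown below. What is called first, only, known or untested is meant among the compounds shown, and "the series" means these compounds.

In a functional assay on MV4-11 cells (Homo sapiens) for antiproliferative activity, read by CellTiter-Glo, with a stated time of 72 h (on this read-out lower numbers stand for stronger inhibition of growth and higher numbers for weaker inhibition of growth), compound 3 (`COCCN[C@H]1CC[C@H](Nc2cc(-c3csc(NCc4ccccc4)n3)c(Cl)cn2)CC1`) gives 330 nM and lies within the scatter of both compound 1 (`COCCN[C@H]1CC[C@H](Nc2cc(-c3csc(SCC4CCOCC4)n3)c(Cl)cn2)CC1`) at 340 nM and compound 2 (`CNc1nc(-c2cc(N[C@H]3CC[C@H](NCCOC)CC3)ncc2Cl)cs1`) at 530 nM alike. Compound 4 (`COCCN[C@H]1CC[C@H](Nc2cc(-c3csc(NCC4CCOC4)n3)c(Cl)cn2)CC1`) has oxolan-3-yl in place of phenyl on a saturated chain carbon bound to a nitrogen on an aromatic ring. Among the compounds with values here, two measured steps bear on this. Phenyl in place of hydrogen at that carbon gave a 1.6-fold lower number from compound 2 to compound 3 (0.21 log units; within the scatter) and benzylamino in place of ((oxan-4-yl)methyl)sulfanyl gave a 1.0-fold lower number from compound 1 to compound 3 (0.01 log units; within the scatter) as well. Neither leaves the scatter, so no step beyond the scatter is expected in this assay here. The estimated change is a 1.2-fold higher number from compound 3 to compound 4 (0.08 log units; within the scatter) for now. Compound 4 is expected at 400 nM within a range of 200 nM to 800 nM in this series.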

Compound 4, concentration for 50% growth inhibition: 493 nM
Estimate against measurement, compound 4: 1.2-fold (0.09 log units) below, within the range that was stated.
By their numbers in this assay, from the lowest: compounds 3, 1, 4 and 2 (each within the scatter of the next).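

In this assay, a saturated ring carrying an oxygen, oxolan-3-yl, can replace phenyl on this saturated chain carbon while the change stays within the scatter (a 1.5-fold higher number from compound 3 to compound 4 (0.17 log units; within the scatter)). The same holds for oxolan-3-yl in place of hydrogen (a 1.1-fold lower number from compound 2 to compound 4 (0.03 log units; within the scatter)) and for the remaining step (a 1.5-fold higher number from compound 1 to compound 4 (0.16 log units; within the scatter)), so hydrogen, phenyl and oxolan-3-yl at this carbon are not separated here. No supporting data explain this result.

Still open, as far as these compounds go, is whether a piperidin-4-yl amine or a carboxylic acid at this carbon would give a step beyond the scatter.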